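Swapping the aminophenyl for dichlorophenyl on the ketone

A few compounds are considered here, and "the series" means these few. Any claim that something is new, unique, unknown or untested is made for them only; others in the source may bear on it.

Compound 2 `COc1cc(-c2cc(/C=C/C(=O)c3ccc(N)cc3)[nH]n2)cc(OC)c1OC` and compound 1 `COc1ccc(-c2cc(/C=C/C(=O)c3ccc(N)cc3)[nH]n2)cc1` were both tested in a functional assay on Malme-3M cells (Homo sapiens) for inhibition, read by sulforhodamine B assay, with a stated time of 48 h; a lower number here means a stronger inhibitor of growth, a higher number a weaker inhibitor of growth. There compound 2 gives 2050 nM, the lower of the two numbers, while compound 1 gives 2180 nM; the gap between them lies within the scatter. Compound 3 `COc1cc(-c2cc(/C=C/C(=O)c3ccc(Cl)c(Cl)c3)[nH]n2)cc(OC)c1OC` has not yet been measured. It differs from compound 2 by 3,4-dichlorophenyl in place of 4-aminophenyl on a carbonyl carbon. Going by the values given here, no comparable step between measured compounds is available, so the expected change a 1.4-fold lower number from compound 2 to compound 3 (0.14 log units; within the scatter) in this assay is modest and may not exceed the scatter. For compound 3 the estimated value is 1500 nM, within a range from 400 nM to 6000 nM.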

Compound 3, concentration for 50% growth inhibition: 29200 nM
Estimate against measurement, compound 3: 19-fold (1.29 log units) below; the whole stated range lies below it.
By their numbers in this assay, from the lowest: compounds 2 and 1 (each within the scatter of the next); then compound 3.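

The group on the carbonyl carbon matters in this assay: 3,4-dichlorophenyl in place of 4-aminophenyl gives a 14-fold higher number from compound 2 to compound 3 (1.15 log units; beyond the scatter) and so a large loss of growth inhibition. Going by these compounds alone, compound 1 and compound 2 differ elsewhere in the molecule and lie within the scatter of each other, so only this step shows that the assay responds to a change at this position. No measurement shown here accounts for the loss.

From the compounds shown here alone, it remains open whether a plain phenyl or a 4-chlorophenyl on the carbonyl carbon would read like compound 2 or like compound 3. The step therefore cannot yet be divided between losing the amine and gaining the chlorines.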